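Replacing methyl with fluoro on a weak growth inhibitor

This account rests on a few compounds, and the source may have more. Where it says the series, first, only, none or still open, it means among the compounds named here.

Measured compounds (a functional assay on A498 cells (Homo sapiens) for cytotoxicity; on this read-out lower numbers stand for stronger inhibition of growth and higher numbers for weaker inhibition of growth)
- Compound 1 `COc1ccc(C2=C(c3ccc(SC)cc3)CC3CCCN3C2=O)cc1C` gives 400 nM
- Compound 2 `CSc1ccc(C2=C(c3ccc(C)cc3)C(=O)N3CCCC3C2)cc1` gives 4000 nM

Of the two measured compounds, compound 2 has the higher number (4000 nM) and so is the weaker inhibitor of growth. The next compound to be tested in this assay is compound 3 `CSc1ccc(C2=C(c3ccc(F)cc3)C(=O)N3CCCC3C2)cc1`. It carries fluoro in place of methyl on an aromatic carbon, para to a large group (fluoro in place of methyl on an aromatic carbon), turning 4-methylphenyl into 4-fluorophenyl.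

Within the data shown here, only one measured step bears on this change: a 10-fold higher number from compound 1 to compound 2 (1.00 log units; beyond the scatter). That step exchanged 4-methoxy-3-methylphenyl for 4-methylphenyl, so it shows that this group can matter. Among the measured compounds shown here, the new change is a smaller edit to the same group, however, and no measured compound carries fluoro, so the data give no direction for it. A step within the usual scatter is the most likely outcome, though a larger one cannot be ruled out. The expected change is a 1.3-fold lower number from compound 2 to compound 3 (0.12 log units; within the scatter). Compound 3 is estimated at 3000 nM, with an expected range from 800 nM to 10000 nM.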

Compound 3, concentration for 50% growth inhibition: 100 nM
Beside the measured number, compound 3's estimate is 30-fold (1.48 log units) above it, and the stated range ends above it.
By their numbers in this assay, from the lowest: compound 3; then compound 1; then compound 2.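

Fluoro in place of methyl swaps one heavy atom for one heavy atom, yet in this assay it gives a 40-fold lower number from compound 2 to compound 3 (1.60 log units; beyond the scatter) and so shows that a single atom on this aromatic carbon, para to a large group, can strongly shift growth inhibition, something the earlier exchange of a whole substituted phenyl group could not show. The 4-fluorophenyl group also compares well with the 4-methoxy-3-methylphenyl group, with a 4.0-fold lower number from compound 1 to compound 3 (0.60 log units; beyond the scatter) in the same read-out, so among these three compounds the order from lowest number to highest is compound 3, compound 1, compound 2, with each gap beyond the usual scatter. Nothing available here accounts for why so small an edit has so large an effect.

The three compounds cannot tell whether the gain is particular to fluoro or would also appear with chloro, hydroxyl, trifluoromethyl or an amine at this position. They also leave open whether the same swap would give a similar step on the 4-(methylthio)phenyl group or on a different arrangement of the two aromatic rings around the shared core.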